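This account rests on a few compounds, and the source may have more. Where it says the series, first, only, none or still open, it means among the compounds named here.

Measured compounds:
compound 1 `C#Cc1cccc(NC(=O)CCc2cccc3c2B(O)OC3)c1` gives 980 nM
compound 2 `C#Cc1ccccc1NC(=O)CCc1cccc2c1B(O)OC2` gives 820 nM
compound 3 `O=C(CCc1cccc2c1B(O)OC2)Nc1ccccc1-c1ccccc1` gives 26000 nM

In a functional assay on SK-OV-3 cells (Homo sapiens) for antiproliferative activity, read by MTT assay, with a stated time of 72 h (on this read-out higher numbers stand for weaker inhibition and lower numbers for stronger inhibition), compound 1 gives 980 nM and compound 2 gives 820 nM; the two values lie within the scatter of each other. Compound 1 and compound 2 are built from the same atoms joined differently; the difference between the two cores is not broken down here. Compound 3 differs from compound 2 by phenyl in place of ethynyl on an aromatic carbon, and that change gives a 32-fold higher number from compound 2 to compound 3 (1.50 log units; beyond the scatter).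

Compound 4 `O=C(CCc1cccc2c1B(O)OC2)Nc1cccc(-c2ccccc2)c1` is not yet measured. It differs from compound 1 by phenyl in place of ethynyl on an aromatic carbon. The place differs from the change leading to compound 3: there the phenyl enters ortho to a large group, here meta to a large group, so this is the same kind of change, not the same change. The step from compound 1 to compound 4 is expected to be a 15-fold higher number from compound 1 to compound 4 (1.18 log units; beyond the scatter), set beside a 32-fold higher number from compound 2 to compound 3 (1.50 log units; beyond the scatter), with the starting point being compound 1 at 980 nM; the different place leaves the size less certain. Compound 4 is estimated at 15000 nM, expected between 3500 nM and 60000 nM.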

Compound 4, half-maximal inhibitory concentration: 250 nM
The estimate for compound 4 lay 60-fold (1.78 log units) above the measured number, outside the stated range (below it).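

In this assay, phenyl in place of ethynyl on an aromatic carbon, meta to a large group, gives a 3.9-fold lower number from compound 1 to compound 4 (0.59 log units; beyond the scatter), so this change does not carry from one core to the other with the same direction or size: the same change on two cores in this assay, a 32-fold higher number (1.50 log units; beyond the scatter) from compound 2 to compound 3 and a 3.9-fold lower number (0.59 log units; beyond the scatter) from compound 1 to compound 4, 120-fold (2.09 log units) apart, beyond the scatter of two such steps

The two parent compounds, compound 1 and compound 2, lie within the scatter of each other, so the parent values alone gave no sign of this split, and a step read on one of these cores cannot be applied to the other. The data do not show what causes the split, and with a single pair on each core they give no general rule for the series.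

Still open, from the compounds shown here alone, is whether other groups at the same place on the core of compound 1, such as an amine, a carboxylic acid or a methoxy group, follow compound 4 or compound 3. Also open, going by these compounds, is whether a longer chain between the amide and the boron-bearing ring system would keep the split between the two cores.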